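The source may hold more compounds than are shown below. What is called first, only, known or untested is meant among the compounds shown, and "the series" means these compounds.

Compound 1, `CCO/C(O)=C1\C(COCCN2CC(=O)N=C2N)=NC(C)=C(C(=O)OC)C1c1ccccc1Cl`, belongs to a pair of dihydropyridines tested in a functional assay (aorta) with Rattus norvegicus as the target (on this read-out higher numbers stand for weaker inhibition and lower numbers for stronger inhibition), where compound 1 gives 20 nM. This is the higher of the two numbers recorded; its only companion, compound 2, `CCO/C(O)=C1\C(COCCN2CC(=O)NC2=O)=NC(C)=C(C(=O)OC)C1c1cccc(Cl)c1Cl`, gives 3.16 nM in this assay, a gap beyond the scatter, though the two differ in more than one place and nothing more can be read from that pair than the two values themselves.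

Compound 3, `CCO/C(O)=C1\C(COCCn2c(N)cnc2O)=NC(C)=C(C(=O)OC)C1c1ccccc1Cl`, has not been measured. It differs from compound 1 in one place: a group of 7 heavy atoms (3 carbon, 3 nitrogen, 1 oxygen; one five-membered aromatic ring with 2 hetero atoms) in place of a group of 7 heavy atoms (3 carbon, 3 nitrogen, 1 oxygen; one five-membered non-aromatic ring with 2 hetero atoms), on a saturated chain carbon, two bonds along the chain from an oxygen on a saturated carbon. The two compounds hold the same atoms, joined differently, so the change reshapes the ring-bearing end of the chain without adding or removing anything.

Going by the values given here, no measured pair isolates such a change, so the direction cannot be taken from the data. He would expect the step from compound 1 to compound 3 in this assay to be small, a 1.3-fold higher number from compound 1 to compound 3 (0.10 log units; within the scatter), and likely within the scatter, with either direction possible. On that basis compound 3 is estimated at 25 nM in this assay, in a range of 6 nM to 100 nM.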

Compound 3, half-maximal inhibitory concentration: 158 nM
The estimate for compound 3 lay 6.3-fold (0.80 log units) below the measured number; measured number above the stated range.
By their numbers in this assay, from the lowest: compound 2; then compound 1; then compound 3.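

Placing the 5-amino-2-hydroxy-1H-imidazol-1-yl group on the saturated chain carbon, in place of the non-aromatic five-membered ring and with the same atoms, gives a 7.9-fold higher number from compound 1 to compound 3 (0.90 log units; beyond the scatter) in this assay. Going by these compounds alone, this is the first change at this place that can be read on its own, which the earlier pair could not show because its members differ in more than one place. It shows that at the end of this chain, the way the same atoms are joined can alone move the read-out beyond the scatter, here towards weaker inhibition, and nothing available accounts for the step.

The compounds shown leave open whether an isomer is the only kind of change that matters here, since a simple amine, a carboxylic acid or a longer chain ending in the same ring cannot be compared at this place. Within the data shown here, they also leave open whether the same swap would give a step of similar size on a phenyl ring carrying a second chlorine, as in compound 2, where only the single value 3.16 nM stands.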